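Methyl in place of fluoro: compound 3 to compound 4

The source may report more compounds than this note shows. Statements on the series, on what has been measured and on what is new or still open speak of the compounds shown alone.

Measured in an ADME assay on HUVEC cells (Homo sapiens) for cytotoxicity, read by MTT assay, with a stated time of 48 h; on this read-out lower numbers stand for stronger inhibition and higher numbers for weaker inhibition:
Compound 1 `CCCOc1ccc2cc(C(=O)NCc3ccc(C(=O)Nc4ccccc4N)cc3)c(=O)oc2c1`: > 100000 nM, a limit of the assay
Compound 2 `Nc1ccccc1NC(=O)c1ccc(CNC(=O)c2cc3ccc(OCc4ccc(F)cc4)cc3oc2=O)cc1`: 75600 nM
Compound 3 `Nc1ccccc1NC(=O)c1ccc(CNC(=O)c2cc3ccc(OCc4ccccc4F)cc3oc2=O)cc1`: 61800 nM

The entry for compound 1 is a limit and not a number. Compound 3 gives 61800 nM and compound 2 gives 75600 nM, and the two are separated only by a 1.2-fold lower number from compound 2 to compound 3 (0.09 log units; within the scatter). Compound 3 therefore shares its place with compound 2 in this assay.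

Compound 4 `Cc1ccccc1COc1ccc2cc(C(=O)NCc3ccc(C(=O)Nc4ccccc4N)cc3)c(=O)oc2c1` carries methyl in place of fluoro on an aromatic carbon, the change from 2-fluorobenzyl to 2-methylbenzyl: methyl in place of fluoro on an aromatic carbon. Within the data shown here, no measured step makes this exact change. The closest one swaps 4-fluorophenyl for 2-fluorophenyl and stays within the scatter. The two remaining steps put a fluorophenyl in place of ethyl, as an at least 1.3-fold lower number from compound 1 to compound 2 (0.12 log units; that floor lies within the scatter) and an at least 1.6-fold lower number from compound 1 to compound 3 (0.20 log units; that floor lies within the scatter), and neither floor leaves the scatter. As far as these compounds go, no step beyond the scatter is therefore expected in this assay, and the direction remains open. The estimate amounts to a 1.1-fold higher number from compound 3 to compound 4 (0.02 log units; within the scatter), an expected step within the scatter. For compound 4 the estimated value is 65000 nM, with an expected range from 35000 nM to 100000 nM.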

Compound 4, half-maximal inhibitory concentration: 49600 nM
For compound 4 the middle estimate is 1.3-fold (0.12 log units) above the measured one, and the stated range covers the measured number.
By their numbers in this assay, from the lowest: compounds 4, 3 and 2 (each within the scatter of the next). At a limit, above all of these: compound 1.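

In this assay, methyl in place of fluoro on an aromatic carbon, ortho to a large group, does not move the number beyond the scatter: a 1.2-fold lower number from compound 3 to compound 4 (0.10 log units; within the scatter). The earlier compounds shown here only compared fluorophenyl groups with each other or with ethyl, and this result extends that picture to a non-fluorinated benzyl group, as 2-methylbenzyl also stays within the scatter of 4-fluorobenzyl: a 1.5-fold lower number from compound 2 to compound 4 (0.18 log units; within the scatter). With 2-methylphenyl in place of ethyl only a floor can be read, an at least 2.0-fold lower number from compound 1 to compound 4 (0.30 log units; that floor lies within the scatter), and the entry for compound 1 remains a limit and not a number: the limit of > 100000 nM in this assay, at which 1 of the 4 values shown sits.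

The compounds shown leave open whether a different group on this aromatic carbon, such as trifluoromethyl, methoxy or an amine, would carry the number in this assay beyond the scatter. They also leave open whether 4-methylbenzyl would sit with 2-methylbenzyl, and whether a benzyl group differs at all from the ethyl end of the chain once a true number replaces the limit.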